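This account rests on a few compounds, and the source may have more. Where it says the series, first, only, none or still open, it means among the compounds named here.

Working notes on the series.

Three compounds with a shared core have numbers in an assay on isolated protein for displacement of a labelled ligand from melanin-concentrating hormone receptor 1 (Homo sapiens); on this read-out higher numbers stand for weaker inhibition and lower numbers for stronger inhibition. Compound 1 `CC(C)N(C)c1ccc2cc(NC(=O)CCc3ccc(C(F)(F)F)cc3)ccc2n1` gives 2 nM. Compound 2 `CCN(CC)c1ccc2cc(NC(=O)CCc3ccc(C(F)(F)F)cc3)ccc2n1` gives 88 nM, and the step of a 44-fold higher number from compound 1 to compound 2 (1.64 log units; beyond the scatter) is the widest in the set. Compound 3 `CC(=O)NC1CCN(c2ccc3cc(NC(=O)CCc4ccc(C(F)(F)F)cc4)ccc3n2)C1` gives 5 nM; it stands second of the three, separated from compound 1 by a 2.5-fold higher number from compound 1 to compound 3 (0.40 log units; beyond the scatter) and from compound 2 by an 18-fold lower number from compound 2 to compound 3 (1.25 log units; beyond the scatter).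

Compound 4 `CC1CCN(c2ccc3cc(NC(=O)CCc4ccc(C(F)(F)F)cc4)ccc3n2)C1` is not yet measured. Its change from compound 3 is methyl in place of acetamido on a saturated ring carbon. Among the measured compounds shown here, no measured step touches the acetamido itself: the three steps in hand all exchange the whole amine on the aromatic carbon, and they show that a cyclic amine (compound 3) and a branched open-chain amine (compound 1) sit close together while the diethylamino of compound 2 lies far off. A methyl on the ring carbon keeps the ring of compound 3 and leaves a small group where the acetamido was, so the step of a 1.3-fold lower number from compound 3 to compound 4 (0.10 log units; within the scatter) is expected to stay within the scatter, with a wide allowance. For the measured compounds named here, the acetamido has no precedent here. The expected value for compound 4 in this assay is 4 nM, within 1 nM to 20 nM.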

Compound 4, half-maximal inhibitory concentration: 2 nM
The estimate for compound 4 lay 2.0-fold (0.30 log units) above the measured number; the range from low to high includes it.
By their numbers in this assay, from the lowest: compounds 1 and 4 (each within the scatter of the next); then compound 3; then compound 2.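

In this assay, the first change made on the saturated ring carbon, two ring bonds from the ring nitrogen, gives a 2.5-fold lower number from compound 3 to compound 4 (0.40 log units; beyond the scatter), so the acetamido with its hydrogen-bond donor and acceptor is not needed for a low number at this position, and the single methyl carbon does modestly better. With methyl in place, the cyclic amine can no longer be told apart from the branched open-chain amine, at no change at the digits printed from compound 1 to compound 4 (within the scatter), while the gap to the diethylamino remains large, at a 44-fold lower number from compound 2 to compound 4 (1.64 log units; beyond the scatter). Nothing measured here accounts for the step from acetamido to methyl, and no supporting evidence bears on it.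

The compounds shown do not say whether the methyl itself matters or only the loss of the acetamido, a question that the bare pyrrolidin-1-yl, with hydrogen on that ring carbon, would address. On these data alone, how far this position tolerates other groups also stays open, for example a hydroxyl, a primary amine, a carboxylic acid or a longer chain such as propyl.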